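Working notes: from compound 2 to compound 3

This account rests on a few compounds, and the source may have more. Where it says the series, first, only, none or still open, it means among the compounds named here.

Measured so far:
compound 1 `COc1cc2c(cc1N1C[C@@H](C)N[C@@H](C)C1)N(C(=O)c1ccc(-c3cccc(C)n3)c3ccccc13)CC2`: 126 nM
compound 2 `COc1cc2c(cc1N1C[C@@H](C)N(C)[C@@H](C)C1)N(C(=O)c1cccc(Cl)c1Cl)CC2`: 251 nM

Both numbers come from an assay on isolated protein for binding affinity to 5-hydroxytryptamine receptor 1D (Homo sapiens); on this read-out higher numbers stand for weaker inhibition and lower numbers for stronger inhibition. Compound 2 gives the highest of the two numbers; compound 1 gives the nearest, a somewhat lower number, and the gap between the two lies within the scatter, so no order between compound 1 and compound 2 is claimed.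

Compound 3 `COc1cc2c(cc1N1C[C@@H](C)N(C)[C@@H](C)C1)N(C(=O)Nc1cccc(Cl)c1F)CC2` has not been measured yet. It differs from compound 2 in one place: (3-chloro-2-fluorophenyl)amino in place of 2,3-dichlorophenyl on a carbonyl carbon. Within the data shown here, no step between two measured compounds is available for comparison, so nothing measured tells the size of this change in this assay. The expectation is a change of no more than the scatter, in either direction, with a slight lean toward a higher number.

Compound 3 is expected to give 320 nM, with a range from 100 nM to 1000 nM. The expected step is a 1.3-fold higher number from compound 2 to compound 3 (0.11 log units; within the scatter).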

Compound 3, inhibition constant: 200 nM
For compound 3 the middle estimate is 1.6-fold (0.20 log units) above the measured one; the range from low to high includes it.
By their numbers in this assay, from the lowest: compounds 1, 3 and 2 (each within the scatter of the next).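

In this assay the swap of 2,3-dichlorophenyl for (3-chloro-2-fluorophenyl)amino on a carbonyl carbon reads a 1.3-fold lower number from compound 2 to compound 3 (0.10 log units; within the scatter) and gives the series its first step that differs in one place. It shows that this carbonyl carbon can carry either group, including the one that brings a hydrogen-bond donor and a nitrogen, with compound 2 and compound 3 staying within the scatter of each other. No supporting measurement bears on why the two compounds read alike.

The step changes the linking nitrogen and the fluorine together, so it cannot assign any share of the outcome to either alone. Still open, going by these compounds, is how this position reads with an N-methylamino link, a benzylamino group or a pyridyl ring on the same carbonyl carbon.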